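The source may report more compounds than this note shows. Statements on the series, on what has been measured and on what is new or still open speak of the compounds shown alone.

Measured so far, in an assay for inhibition of Nicotinamide phosphoribosyltransferase (Homo sapiens), read by mass spectrometry, with stated times of 15 min and 30 min; on this read-out lower numbers stand for stronger inhibition and higher numbers for weaker inhibition:

Compound 1, `O=C(NCc1ccc(S(=O)(=O)c2ccccc2)cc1)c1cc2ccncc2s1`, gives 7 nM.
Compound 2, `O=C(NCc1ccc(S(=O)(=O)c2ccccc2)cc1)c1ccc2nccn2c1`, gives 18 nM.
Compound 3, `O=C(NCc1ccc(S(=O)(=O)c2cccc(C(F)(F)F)c2)cc1)c1ccc2nccn2c1`, gives 8 nM.

All three share a long arm ending in a sulfone-linked ring, joined through an amide to a two-ring aromatic head. Two changes have been tried on this frame. Exchanging the head, (a group of 9 heavy atoms (7 carbon, 1 nitrogen, 1 sulfur; one five-membered aromatic ring with 1 hetero atom, one six-membered aromatic ring with 1 hetero atom) in place of a group of 9 heavy atoms (7 carbon, 2 nitrogen; one five-membered aromatic ring with 2 hetero atoms, one six-membered aromatic ring with 1 hetero atom), on a carbonyl carbon), gave a 2.6-fold lower number from compound 2 to compound 1 (0.41 log units; beyond the scatter). Adding a group on the far ring, (trifluoromethyl in place of hydrogen on an aromatic carbon), gave a 2.3-fold lower number from compound 2 to compound 3 (0.35 log units; beyond the scatter). Compounds 1 and 3 give numbers that lie within the usual scatter of each other, so no order between them is claimed.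

Compound 4, `O=C(NCc1ccc(S(=O)(=O)c2cccc(C(F)(F)F)c2)cc1)c1cc2ccncc2s1`, carries both changes at once. It differs from compound 3 by a group of 9 heavy atoms (7 carbon, 1 nitrogen, 1 sulfur; one five-membered aromatic ring with 1 hetero atom, one six-membered aromatic ring with 1 hetero atom) in place of a group of 9 heavy atoms (7 carbon, 2 nitrogen; one five-membered aromatic ring with 2 hetero atoms, one six-membered aromatic ring with 1 hetero atom), on a carbonyl carbon, the same change that turns compound 2 into compound 1, at the same place; this head exchange thus occurs twice among the compounds shown. The cores on which it is made differ by trifluoromethyl in place of hydrogen on an aromatic carbon, the change from compound 2 to compound 3.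

Compound 4 is expected to give 3 nM in this assay, that is a step of a 2.7-fold lower number from compound 3 to compound 4 (0.43 log units; beyond the scatter) from compound 3, because the same head exchange gave a 2.6-fold lower number from compound 2 to compound 1 (0.41 log units; beyond the scatter) and compound 3 starts from 8 nM. This rests on a single earlier instance of the change, so the range is kept wide: compound 4 is estimated to fall between an expected lower end of 1.5 nM and an expected upper end of 7 nM.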

Compound 4, half-maximal inhibitory concentration: 3 nM
For compound 4 middle estimate and measured number coincide at the digits printed; the measured number falls inside the stated range.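

In this assay, the head exchange again lowers the number, with a 2.7-fold lower number from compound 3 to compound 4 (0.43 log units; beyond the scatter), and its size on the two cores agrees: the same change on two cores in this assay, a 2.6-fold lower number (0.41 log units; beyond the scatter) from compound 2 to compound 1 and a 2.7-fold lower number (0.43 log units; beyond the scatter) from compound 3 to compound 4, 1.0-fold (0.02 log units) apart, within the scatter of two such steps. The other change, trifluoromethyl in place of hydrogen on an aromatic carbon, gives a 2.3-fold lower number from compound 1 to compound 4 (0.37 log units; beyond the scatter) and also keeps its size: the same change on two cores in this assay, a 2.3-fold lower number (0.35 log units; beyond the scatter) from compound 2 to compound 3 and a 2.3-fold lower number (0.37 log units; beyond the scatter) from compound 1 to compound 4, 1.0-fold (0.02 log units) apart, within the scatter of two such steps. Together, compounds 1, 2, 3 and 4 show that each change had about the same effect whether or not the other was present, so here the two steps simply add up, but this is one set of four compounds in one assay and shows neither why this happens nor that it would hold on other cores.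

The compounds shown leave open whether the head exchange would keep this size with a methoxy group or a chlorine atom in place of trifluoromethyl, or with a longer chain in the arm that joins the amide to the sulfone. They also leave open whether the same agreement would appear with a head carrying an amine or a carboxylic acid.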